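The source may hold more compounds than are shown below. What is called first, only, known or untested is meant among the compounds shown, and "the series" means these compounds.

Measured so far in an assay on isolated protein for displacement of a labelled ligand from metabotropic glutamate receptor 5 (Homo sapiens), with a stated time of 60 min, tested at 1 uM; a lower number here means less inhibition, a higher number more inhibition at the concentration tested (going by the name of the read-out):
- compound 1 `CC1CCN(c2c(S(=O)(=O)c3ccc(F)cc3)cnc3ccc(F)cc23)CC1` gives 87%
- compound 2 `Cc1cc(C)cc(S(=O)(=O)c2cnc3ccc(C)cc3c2N2CCC(C)CC2)c1` gives 80%
- compound 3 `Cc1cc(C)cc(S(=O)(=O)c2cnc3ccc(F)cc3c2N2CCC(C)CC2)c1` gives 83%

Compound 3 stands second of the three numbers, with a number 3 percentage points higher from compound 2 to compound 3 (within the scatter) and a number 4 percentage points lower from compound 1 to compound 3 (within the scatter), so all three lie within the scatter of one another; no order can be read among them.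

Compound 4 `CC1CCN(c2c(S(=O)(=O)c3cccc(F)c3)cnc3ccc(F)cc23)CC1` differs from compound 3 in one place: 3-fluorophenyl in place of 3,5-dimethylphenyl on a sulfonyl sulfur. Within the data shown here, two steps bear on it. The exchange of the aryl group on the sulfonyl sulfur gave a number 4 percentage points lower from compound 1 to compound 3 (within the scatter), and fluoro for methyl on an aromatic carbon gave a number 3 percentage points higher from compound 2 to compound 3 (within the scatter); both were within the scatter. A step of similar size, not beyond the scatter, is therefore expected here, estimated as a number 2 percentage points higher from compound 3 to compound 4 (within the scatter). Compound 4 is expected to give about 85%, within 72% to 94%.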

Compound 4, a percentage reported as inhibition, at one concentration (the size of the read-out at that concentration, not a potency): 76%
For compound 4 the middle estimate is 9 percentage points above the measured one; the range from low to high includes it.
By their numbers in this assay, from the lowest: compounds 4, 2, 3 and 1 (each within the scatter of the next, the first and the last beyond it).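

Among these compounds, with a number 11 percentage points lower from compound 1 to compound 4 (beyond the scatter) on moving to 3-fluorophenyl from 4-fluorophenyl, the sulfonyl aryl group gives the first step beyond the scatter. The exchange for 3,5-dimethylphenyl, with a number 7 percentage points lower from compound 3 to compound 4 (within the scatter), stays within it, so at this position only the two fluorophenyl groups are told apart. No available measurement accounts for this step.

Open, going by these compounds, is whether a cyclohexyl group or a pyridyl ring on the sulfonyl sulfur keeps the inhibition. Also open, on these data alone, is whether the step between the two fluorophenyl groups holds with methyl in place of fluoro on the core.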